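Amine Swap on the Acrylamide Tail: Expectation for Compound 4

This account rests on a few compounds, and the source may have more. Where it says the series, first, only, none or still open, it means among the compounds named here.

The measured compounds:
Compound 1, `CCN(CC)C/C=C/C(=O)Nc1cc2c(N3CCc4ccccc43)ncnc2cc1O[C@@H]1CCOC1`, gives 4980 nM in a functional assay on MCF7 cells (Homo sapiens) for antiproliferative activity, read by MTT assay, with a stated time of 72 h; on this read-out lower numbers stand for stronger inhibition and higher numbers for weaker inhibition.
Compound 2, `O=C(/C=C/CN1CCCC1)Nc1cc2c(N3CCc4ccccc43)ncnc2cc1O[C@@H]1CCOC1`, gives 2310 nM in this assay.
Compound 3, `CCN(CC)C/C=C/C(=O)Nc1cc2c(N3CCCc4ccccc43)ncnc2cc1O[C@@H]1CCOC1`, gives 3870 nM in this assay.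

Compound 4, `O=C(/C=C/CN1CCCC1)Nc1cc2c(N3CCCc4ccccc43)ncnc2cc1O[C@@H]1CCOC1`, is not yet measured. It stands to compound 3 as compound 2 stands to compound 1: the change is pyrrolidin-1-yl in place of diethylamino on a saturated chain carbon bound to a double-bonded chain carbon, and the earlier instance is pyrrolidin-1-yl in place of diethylamino on a saturated chain carbon bound to a double-bonded chain carbon. The two place lines read the same word for word, so the change is the same one, made on two cores. The cores differ by 1,2,3,4-tetrahydroquinolin-1-yl in place of 2,3-dihydro-1H-indol-1-yl on an aromatic carbon, a step that gave a 1.3-fold lower number from compound 1 to compound 3 (0.11 log units; within the scatter) in this assay. The earlier instance of the amine swap gave a 2.2-fold lower number from compound 1 to compound 2 (0.33 log units; beyond the scatter).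

From compound 3 to compound 4, a step of a 2.0-fold lower number from compound 3 to compound 4 (0.31 log units; beyond the scatter) in this assay is expected, resting on compound 1 and compound 2 because a 2.2-fold lower number from compound 1 to compound 2 (0.33 log units; beyond the scatter), and on compound 3 because 3870 nM. The number for compound 4 is therefore estimated at 1900 nM, expected to fall between 900 nM and 4000 nM.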

Compound 4, half-maximal inhibitory concentration: 4250 nM
Compound 4: the middle estimate sits 2.2-fold (0.35 log units) below what was measured; the measured number lies above the stated range.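

In this assay, the swap to pyrrolidin-1-yl from diethylamino on the core carrying 1,2,3,4-tetrahydroquinolin-1-yl gives a 1.1-fold higher number from compound 3 to compound 4 (0.04 log units; within the scatter), and the ring change with the pyrrolidin-1-yl tail in place gives a 1.8-fold higher number from compound 2 to compound 4 (0.26 log units; within the scatter). Set beside its earlier instance, the amine swap cannot be said to behave differently on the two cores, yet it is not shown to carry over either, since only the earlier step lies beyond the scatter: the same change on two cores in this assay, a 2.2-fold lower number (0.33 log units; beyond the scatter) from compound 1 to compound 2 and a 1.1-fold higher number (0.04 log units; within the scatter) from compound 3 to compound 4, 2.4-fold (0.37 log units) apart, within the scatter of two such steps. The ring change, read with the two tails, likewise shows no dependence on the tail, though four compounds cannot establish that the two changes act independently: the same change on two cores in this assay, a 1.3-fold lower number (0.11 log units; within the scatter) from compound 1 to compound 3 and a 1.8-fold higher number (0.26 log units; within the scatter) from compound 2 to compound 4, 2.4-fold (0.37 log units) apart, within the scatter of two such steps.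

The compounds shown leave open whether a piperidin-1-yl, morpholin-4-yl or dimethylamino group on the same chain carbon would follow pyrrolidin-1-yl on these two cores. They also leave open how the amine swap reads on a core with an anilino group on that aromatic carbon.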